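Working notes: fluoro for trifluoromethyl on compound 3

The source may report more compounds than this note shows. Statements on the series, on what has been measured and on what is new or still open speak of the compounds shown alone.

Values in a functional assay on ACHN cells (Homo sapiens); a lower number here means a stronger inhibitor of growth, a higher number a weaker inhibitor of growth:
- compound 1 `O=S(=O)(/C=C/c1ccc(F)cc1F)Cc1ccc(Nc2ncnc3ccccc23)cc1`: 31000 nM
- compound 2 `O=S(=O)(/C=C/c1ccc(Cl)cc1Cl)Cc1ccc(Nc2ncnc3ccc(Br)cc23)cc1`: 100 nM
- compound 3 `O=S(=O)(/C=C/c1ccc(C(F)(F)F)cc1F)Cc1ccc(Nc2ncnc3ccc(Br)cc23)cc1`: 16000 nM

Compound 3 gives 16000 nM, within the scatter of compound 1 at 31000 nM. Among the measured compounds shown here, the one measured step, a 160-fold higher number from compound 2 to compound 3 (2.20 log units; beyond the scatter), puts compound 3 well away from compound 2 .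

Next is compound 4 `O=S(=O)(/C=C/c1ccc(F)cc1F)Cc1ccc(Nc2ncnc3ccc(Br)cc23)cc1`, not yet measured in this assay. The change is fluoro in place of trifluoromethyl on an aromatic carbon, giving a 2,4-difluorophenyl group.

The measured step bears directly on this aromatic group, and it is large. For the measured compounds named here, it exchanged 2,4-dichlorophenyl for 2-fluoro-4-(trifluoromethyl)phenyl, but no measured step isolates the trifluoromethyl alone. Compound 1 carries the same 2,4-difluorophenyl group on a different core and gives 31000 nM, which argues against expecting a full return towards compound 2 . The expected change is therefore a moderate move to a lower number, with wide uncertainty: a 5.3-fold lower number from compound 3 to compound 4 (0.73 log units; beyond the scatter).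

For compound 4 the estimated value is 3000 nM, with an expected range of 300 nM to 25000 nM.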

Compound 4, concentration for 50% growth inhibition: 8000 nM
Compound 4: the middle estimate sits 2.7-fold (0.43 log units) below what was measured; low and high end bracket the measured number.
By their numbers in this assay, from the lowest: compound 2; then compounds 4, 3 and 1 (each within the scatter of the next, the first and the last beyond it).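

In this assay, fluoro in place of trifluoromethyl on this aromatic carbon now stands alone as a 2.0-fold lower number from compound 3 to compound 4 (0.30 log units; within the scatter), so the two groups are not told apart at this position. The large step lies with the 2,4-dichlorophenyl group of compound 2, seen in an 80-fold higher number from compound 2 to compound 4 (1.90 log units; beyond the scatter), which shows that fluoro in place of chloro on this aryl group matters far more than the fluoro and trifluoromethyl exchange. Bromo in place of hydrogen on the core, a 3.9-fold lower number from compound 1 to compound 4 (0.59 log units; beyond the scatter), is a modest step with 2,4-difluorophenyl in place.

Nothing available explains these steps. Open, as far as these compounds go, is whether a single chloro carries the value of compound 2 , and whether methyl or methoxy on the same aromatic carbon would follow chloro or fluoro.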